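A few compounds are considered here, and "the series" means these few. Any claim that something is new, unique, unknown or untested is made for them only; others in the source may bear on it.

In a functional assay on HL-60 cells (Homo sapiens) for inhibition, read by MTT assay, with a stated time of 72 h (on this read-out higher numbers stand for weaker inhibition and lower numbers for stronger inhibition), compound 1 `CCc1nc(-c2ccccc2F)c(C(=O)N2CCN(c3cccc(Cl)c3)CC2)o1` gives 139 nM and compound 3 `CCc1nc(-c2ccc(F)cc2)c(C(=O)N2CCN(c3cccc(Cl)c3)CC2)o1` gives 169 nM. Swapping 2-fluorophenyl for 4-fluorophenyl makes a 1.2-fold higher number from compound 1 to compound 3 (0.08 log units; within the scatter), so these two numbers cannot be told apart, and compound 3 stands level with the only other measured number. Compound 2 `O=C(c1oc(C(F)(F)F)nc1-c1cccc(F)c1)N1CCN(c2cccc(Cl)c2)CC1`, which carries a trifluoromethyl group and a differently placed fluorine, is reported in this assay as "not active" (no number reported).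

Compound 4 `O=C(c1oc(C(F)(F)F)nc1-c1ccc(F)cc1)N1CCN(c2cccc(Cl)c2)CC1` is compound 3 with one change: trifluoromethyl in place of ethyl on an aromatic carbon. That carbon lies next to the ring nitrogen and next to the ring oxygen.

Among the measured compounds shown here, no measured step isolates this swap. For the measured compounds named here, the one measured step, a 1.2-fold higher number from compound 1 to compound 3 (0.08 log units; within the scatter), concerns only the fluorine position and stays within the scatter. The closest evidence is therefore compound 2 at "not active" (no number reported), a single compound that gives no number to scale from. A clear loss of inhibition therefore seems likely, although its size is very uncertain. The expected change is an 8.9-fold higher number from compound 3 to compound 4 (0.95 log units; beyond the scatter), toward a higher number and so weaker inhibition. For compound 4 the estimated value is 1500 nM, with an expected range from 250 nM to 10000 nM.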

Compound 4, half-maximal inhibitory concentration: "not active" (no number reported)
Nothing numeric was reported for compound 4, so the estimate cannot be set against anything.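

In this assay, among the compounds shown here, compound 3 gives 169 nM and compound 4 is reported as "not active" (no number reported), so no step of any size can be read between these two compounds. No available evidence bears on this result. Going by these compounds, how far trifluoromethyl in place of ethyl shifts the inhibition in numbers stays open.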